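The source may hold more compounds than are shown below. What is called first, only, known or untested is meant among the compounds shown, and "the series" means these compounds.

Of the compounds shown here, three have been tested in a functional assay on MRC5 cells (Homo sapiens) for inhibition, read by microscopy and resazurin assay, with a stated time of 72 h (on this read-out higher numbers stand for weaker inhibition and lower numbers for stronger inhibition), so far, and none of them gave a number. Compound 1 `CC(C)[C@H](NC(=O)CNC(=O)c1cn(CC(=O)NOCc2ccccc2)c2ccccc12)C(=O)O` is reported only as a limit, > 128000 nM. Compound 2 `C=CCONC(=O)Cn1ccc(C(=O)N[C@@H](C)C(=O)N[C@H](C(=O)O)C(C)C)c1` likewise stands only at a limit, > 128000 nM. Compound 3 `C=CCONC(=O)Cn1ccc(C(=O)N[C@@H](C)C(=O)N[C@@H](CC(C)C)C(=O)O)c1` also reaches only a limit, > 128000 nM. This is summed up by the limit of > 128000 nM in this assay, at which 3 of the 3 values shown sit. Within the data shown here, the single one-place change among the measured compounds, a step that the two limits leave unreadable from compound 2 to compound 3, therefore cannot be read. Compound 4 `CC(C)[C@H](NC(=O)[C@H](C)NC(=O)c1ccn(CC(=O)NOCc2ccccc2)c1)C(=O)O` is not yet measured. It differs from compound 2 by phenyl in place of vinyl on a saturated chain carbon bound to an oxygen on an unsaturated carbon. Among the measured compounds shown here, no measured step bears directly on this change; the only guide is that compound 1, which already carries the benzyloxy group, is itself reported only as a limit. Compound 4 is therefore expected to remain at the limit, with an estimate of 200000 nM, spanning 100000 nM to 600000 nM. The expected step is a step that the limit leaves unreadable from compound 2 to compound 4, which would again not be readable as a step beyond the scatter.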

Compound 4, half-maximal inhibitory concentration: > 128000 nM
Compound 4: no number, only a limit; the forecaster's own chance of this, stated with the estimate: 90%; the middle value is on the limit's open side.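

Compound 4, like compound 2, is reported only as a limit, so no step between the two can be read: the limit of > 128000 nM in this assay, at which 4 of the 4 values shown sit.

The compounds shown leave open what concentration, if any, would give half-maximal inhibition in this assay, and whether phenyl in place of vinyl changes it.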